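The source may hold more compounds than are shown below. What is called first, only, known or untested is meant among the compounds shown, and "the series" means these compounds.

Working notes on the series.

Compound 1 `Cc1ccc2nc(/N=C3\C(=O)N(CN(C)C)c4cccc(Br)c43)sc2c1` carries a dimethylamino group on a saturated chain carbon bound to an amide-type nitrogen in a ring. In an ADME assay on 184B5 cells (Homo sapiens) for cytotoxicity, read by sulforhodamine B assay, with a stated time of 48 h (on this read-out higher numbers stand for weaker inhibition of growth and lower numbers for stronger inhibition of growth), compound 1 gives 74800 nM. Compound 2 `CN(C)CN1C(=O)C(=O)c2c(Br)cccc21` shares the same side group on a smaller core; the difference between the two cores is not broken down here. In this assay compound 2 gives 77900 nM. Compound 3 `O=C1C(=O)N(CN2CCCCC2)c2cccc(Br)c21` differs from compound 2 by piperidin-1-yl in place of dimethylamino on a saturated chain carbon bound to an amide-type nitrogen in a ring. In this assay compound 3 gives 85200 nM, and the step of a 1.1-fold higher number from compound 2 to compound 3 (0.04 log units; within the scatter) is within the scatter, so the two values are not distinguishable. The three measured values also lie within the scatter of one another, so none of them is set apart.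

Compound 4 `Cc1ccc2nc(/N=C3\C(=O)N(CN4CCCCC4)c4cccc(Br)c43)sc2c1` is not yet measured. Within the data shown here, it differs from compound 1 by piperidin-1-yl in place of dimethylamino on a saturated chain carbon bound to an amide-type nitrogen in a ring, which is the same change as the one from compound 2 to compound 3, at a place described in the same words. Because the step of a 1.1-fold higher number from compound 2 to compound 3 (0.04 log units; within the scatter) is within the scatter on the smaller core, the step from compound 1 to compound 4 is expected to be of a similar size, a 1.1-fold higher number from compound 1 to compound 4 (0.03 log units; within the scatter), with the value of compound 1, 74800 nM, as the anchor. On that basis compound 4 is expected to give about 80000 nM in this assay, most likely between 45000 nM and 140000 nM.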

Compound 4, concentration for 50% growth inhibition: 85200 nM
The estimate for compound 4 lay 1.1-fold (0.03 log units) below the measured number; low and high end bracket the measured number.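

On the core of compound 1, piperidin-1-yl in place of dimethylamino on a saturated chain carbon bound to an amide-type nitrogen in a ring gives a 1.1-fold higher number from compound 1 to compound 4 (0.06 log units; within the scatter) in this assay. Set beside the step on the smaller core, this step does not differ from it: the same change on two cores in this assay, a 1.1-fold higher number (0.04 log units; within the scatter) from compound 2 to compound 3 and a 1.1-fold higher number (0.06 log units; within the scatter) from compound 1 to compound 4, 1.0-fold (0.02 log units) apart, within the scatter of two such steps

So, on these two cores, the change carries over as a step too small to separate from the scatter, and both pairs read the same. This does not show that a step of real size would carry over from one core to the other, since neither step here stands clear of the scatter, and two cores and one exchange of groups support no wider rule for the series.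

The compounds shown leave open what other groups at this place would do, for instance morpholin-4-yl, a piperazine ring or a carboxylic acid on the saturated chain carbon. They also leave open whether a longer chain between the amide-type nitrogen and the amine would give a step beyond the scatter on either core, and whether such a step would then match from core to core.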